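Phenyl for Methyl on the Shared Core: Compound 4

The compounds below may be only part of what the source reports. "The series", "measured", "known", "first", "only" and "open" are said of these compounds alone.

Measured compounds:
compound 1 `Cc1ccc2c(c1)c(=O)c(C(=O)Nc1ccc(Oc3ncnc4[nH]cc(-c5ccccc5)c34)c(F)c1)c(C)n2C`: 100 nM
compound 2 `CCn1c(C)c(C(=O)Nc2ccc(Oc3ncnc4[nH]cc(-c5ccccc5)c34)c(F)c2)c(=O)c2cc(C)ccc21`: 150 nM
compound 3 `Cc1ccc2c(c1)c(=O)c(C(=O)Nc1ccc(Oc3ncnc4[nH]cc(-c5ccccc5)c34)c(F)c1)c(C)n2-c1ccccc1`: 620 nM

All three were tested in an assay on isolated protein for inhibition of tyrosine-protein kinase receptor UFO (Homo sapiens), read by FRET and Z'-LYTE, with a stated time of 1.5 h; a higher number here means a weaker inhibitor, a lower number a stronger inhibitor. Compound 1 has the lowest of the three numbers, but its gap to compound 2, a 1.5-fold higher number from compound 1 to compound 2 (0.18 log units; within the scatter), lies within the scatter; only compound 3 is clearly weaker, a 6.2-fold higher number from compound 1 to compound 3 (0.79 log units; beyond the scatter). Compound 4 `Cc1ccc2c(c1)c(=O)c(C(=O)Nc1ccc(Oc3ncnc4[nH]cc(-c5ccccc5)c34)c(F)c1)c(-c1ccccc1)n2C` differs from compound 1 by phenyl in place of methyl on an aromatic carbon. For the measured compounds named here, no measured step puts a phenyl on that carbon; the nearest comparisons are the steps that put a phenyl on the aromatic nitrogen, a 6.2-fold higher number from compound 1 to compound 3 (0.79 log units; beyond the scatter) and a 4.1-fold higher number from compound 2 to compound 3 (0.62 log units; beyond the scatter), both modest and beyond the scatter, whereas the small change a 1.5-fold higher number from compound 1 to compound 2 (0.18 log units; within the scatter) stayed within it. For compound 4 a modest weakening is therefore expected, a 3.0-fold higher number from compound 1 to compound 4 (0.48 log units; beyond the scatter) in this assay. Compound 4 is estimated at 300 nM, with a range of 100 nM to 900 nM.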

Compound 4, half-maximal inhibitory concentration: 78 nM
The estimate for compound 4 lay 3.8-fold (0.59 log units) above the measured number; the measured number lies below the stated range.
By their numbers in this assay, from the lowest: compounds 4, 1 and 2 (each within the scatter of the next); then compound 3.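

Phenyl in place of methyl on the aromatic carbon next to the ring nitrogen gives a 1.3-fold lower number from compound 1 to compound 4 (0.11 log units; within the scatter) in this assay, so this carbon accepts the larger group without a weakening beyond the scatter. The same group on the aromatic nitrogen gave a 6.2-fold higher number from compound 1 to compound 3 (0.79 log units; beyond the scatter), so in this series the outcome of adding a phenyl depends on which of these two atoms carries it. Nothing available explains this difference. As far as these compounds go, whether this carbon would accept an amine, a carboxylic acid or a longer chain remains open, as does the outcome of a substituted phenyl there.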